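The compounds below may be only part of what the source reports. "The series", "measured", "known", "first", "only" and "open" are said of these compounds alone.

Three compounds of this series have a number in an assay on cells (Oocyte) for negative allosteric modulation of glutamate receptor ionotropic, NMDA 2D (Rattus norvegicus), read by two-electrode voltage clamp; a higher number here means a weaker inhibitor, a lower number a stronger inhibitor. Compound 1 `O=C(O)CCC(=O)N1N=C(c2c(-c3ccccc3)c3cc(Cl)ccc3[nH]c2=O)CC1c1ccc([N+](=O)[O-])cc1` gives 1100 nM, compound 2 `O=C(O)CCC(=O)N1N=C(c2c(-c3ccc(Cl)cc3)c3ccccc3[nH]c2=O)CC1c1ccccc1` gives 11000 nM, and compound 3 `COc1ccc(-c2c(C3=NN(C(=O)CCC(=O)O)C(c4ccc(Cl)cc4)C3)c(=O)[nH]c3ccccc23)cc1` gives 2300 nM. Among these three numbers compound 3 stands second highest: its nearest neighbour is compound 1, whose number is lower by a margin beyond the usual scatter, and the furthest is compound 2, whose number is higher, also beyond the scatter. The step under study leads from compound 3 to compound 4 `O=C(O)CCC(=O)N1N=C(c2c(-c3ccc(F)c(Cl)c3)c3ccccc3[nH]c2=O)CC1c1ccc(Cl)cc1`, which has not yet been measured. The change is 3-chloro-4-fluorophenyl in place of 4-methoxyphenyl on an aromatic carbon. Among the compounds with values here, no pair of measured compounds differs in this place alone, so the size of the step cannot be read from a measured pair. Of the measured compounds, compound 2, which also carries a halogen-substituted phenyl rather than a methoxyphenyl here while differing elsewhere as well, shows the highest number. The account therefore expects an upward step of a 2.0-fold higher number from compound 3 to compound 4 (0.29 log units; within the scatter) in this assay, modest but likely beyond the scatter. Compound 4 is estimated at 4500 nM, with a range from 1400 nM to 14000 nM.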

Compound 4, half-maximal inhibitory concentration: 1000 nM
Beside the measured number, compound 4's estimate is 4.5-fold (0.65 log units) above it; the measured number lies below the stated range.
By their numbers in this assay, from the lowest: compounds 4 and 1 (each within the scatter of the next); then compound 3; then compound 2.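

In this assay the place opposite the ring nitrogen now has a step of its own: with the rest of the molecule held fixed, 3-chloro-4-fluorophenyl in place of 4-methoxyphenyl gives a 2.3-fold lower number from compound 3 to compound 4 (0.36 log units; beyond the scatter) as a modest change beyond the scatter. The position therefore responds to the aryl group it carries, and here the halogen-bearing phenyl gives the stronger inhibitor of the pair. Within the data shown here, nothing measured explains this shift, and the single exchange changes the whole ring substitution at once.

As far as these compounds go, it remains open whether the chlorine, the fluorine or the departure of the methoxy group accounts for the step, which a 3-chlorophenyl or a 4-fluorophenyl at this position would help to separate. From the compounds shown here alone, how an amine or a carboxylic acid on this phenyl ring would read also remains open.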